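Fluorophenyl positional swap in an antiproliferative set

The compounds below may be only part of what the source reports. "The series", "measured", "known", "first", "only" and "open" are said of these compounds alone.

compound 1 `O=C(Nc1cccc(C(=O)O/N=C2\CCCc3noc(-c4ccc(F)cc4)c32)c1)c1cccc(F)c1`: in a functional assay on HCC1954 cells (Homo sapiens) for antiproliferative activity, read by MTT assay, with a stated time of 72 h (a higher number here means a weaker inhibitor, a lower number a stronger inhibitor), compound 1 gives > 25000 nM, a limit of the assay.
compound 2 `O=C(Nc1cccc(C(=O)O/N=C2\CCCc3noc(-c4cccc(F)c4)c32)c1)c1cccc(F)c1`: in this assay compound 2 gives > 25000 nM, a limit of the assay.
compound 3 `CC1(C)C/C(=N\OC(=O)c2cccc(NC(=O)c3cccc(F)c3)c2)c2c(-c3ccc(F)cc3)noc2C1`: in this assay compound 3 gives > 25000 nM, a limit of the assay.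

The change from compound 1 to compound 2 is 3-fluorophenyl in place of 4-fluorophenyl on an aromatic carbon. Its step is a step that the two limits leave unreadable from compound 1 to compound 2, unreadable because all values sit at the limit of > 25000 nM in this assay, at which 3 of the 3 values shown sit.

Compound 4 `CC1(C)C/C(=N\OC(=O)c2cccc(NC(=O)c3cccc(F)c3)c2)c2c(-c3cccc(F)c3)noc2C1` is yet to be measured. It differs from compound 3 by 3-fluorophenyl in place of 4-fluorophenyl on an aromatic carbon. The difference between the cores of compound 1 and compound 3 is not broken down here. The two places are not identical: in compound 1 the carbon is next to the ring oxygen and two ring bonds from the ring nitrogen, in compound 3 next to the ring nitrogen and two ring bonds from the ring oxygen, so this is the same kind of change, not the same change.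

Because every measured value sits at the limit of > 25000 nM in this assay, at which 3 of the 3 values shown sit, compound 4 is expected to give no number either. The expected value for compound 4 is 40000 nM, within 20000 nM to 200000 nM. The step this expectation means is a step that the limit leaves unreadable from compound 3 to compound 4.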

Compound 4, half-maximal inhibitory concentration: > 25000 nM
Compound 4 ended at the assay's limit; the forecaster's own chance of this, stated with the estimate: 85%; the middle value does not contradict the limit.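

No step can be read from compound 3 to compound 4, because both compounds give only a limit of the assay, not a number: the limit of > 25000 nM in this assay, at which 4 of the 4 values shown sit.

The compounds shown leave open whether 3-fluorophenyl in place of 4-fluorophenyl changes activity on either core.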